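This account rests on a few compounds, and the source may have more. Where it says the series, first, only, none or still open, it means among the compounds named here.

Measured so far in a functional assay on DLD-1 cells (Homo sapiens) for cytotoxicity, read by MTT assay, with a stated time of 96 h; a higher number here means a weaker inhibitor, a lower number a stronger inhibitor:

compound 1 `OCc1cc(O)c(O)c(Br)c1` gives 51500 nM
compound 2 `OCc1cc(Br)c(O)c(O)c1Br` gives 15000 nM
compound 3 `COCc1cc(O)c(O)c(Br)c1` gives 35300 nM

Compound 2 stands at the lowest of the three numbers in this assay; compound 3 is nearest and compound 1 furthest. Going by the values given here, the one step that reaches compound 2 is a 3.4-fold lower number from compound 1 to compound 2 (0.54 log units; beyond the scatter), and it lies beyond the scatter. The other measured step, a 1.5-fold lower number from compound 1 to compound 3 (0.16 log units; within the scatter), lies within the scatter.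

Compound 4 `CCOCc1cc(Br)c(O)c(O)c1Br` is the next member. Its difference from compound 2 is ethyl in place of hydrogen on an oxygen on a saturated carbon. The step that bears on it is a 1.5-fold lower number from compound 1 to compound 3 (0.16 log units; within the scatter), which is also a change of hydrogen for a small alkyl on an oxygen on a saturated carbon and which did not move the number beyond the scatter. Among the compounds with values here, with ethyl in place of methyl there is no measured step to lean on, so the expectation is a step of no more than the scatter, if anything towards a slightly lower number, estimated as a 1.3-fold lower number from compound 2 to compound 4 (0.10 log units; within the scatter). Compound 4 is therefore expected to give about 12000 nM in this assay, with a range from 5000 nM to 30000 nM.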

Compound 4, half-maximal inhibitory concentration: 7150 nM
Compound 4: middle estimate off by 1.7-fold (0.22 log units), on the high side; the measured number falls inside the stated range.
By their numbers in this assay, from the lowest: compound 4; then compound 2; then compounds 3 and 1 (each within the scatter of the next).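

In this assay the change from hydroxymethyl to ethoxymethyl gives a 2.1-fold lower number from compound 2 to compound 4 (0.32 log units; beyond the scatter), a modest step, but the first on this oxygen to lie beyond the scatter, whereas a 1.5-fold lower number from compound 1 to compound 3 (0.16 log units; within the scatter) stays within it. On the core of compound 2, then, the hydrogen on this oxygen is not required, and ethyl takes its place with a lower number rather than a loss. The two steps differ in both the entering group and the core that carries it, so neither difference can be singled out from these compounds.

Open, on these data alone, is whether a longer chain such as propyl or butyl on this oxygen would lower the number further, and how an amine or a carboxylic acid at this place would compare. No measurement shown here gives a reason for the step.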